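The compounds below may be only part of what the source reports. "The series", "measured", "known", "first", "only" and "open" are said of these compounds alone.

Measured in a functional assay on HeLa cells (Homo sapiens) for antiproliferative activity, read by sulforhodamine B assay, with a stated time of 72 h; a lower number here means a stronger inhibitor, a higher number a weaker inhibitor:
Compound 1 `Fc1ccccc1NC(=S)N/N=C/c1ccc2ccccc2n1`: > 100000 nM (a limit of the assay)
Compound 2 `NC(=S)N/N=C/c1ccc2ccccc2n1`: 960 nM
Compound 3 `S=C(N/N=C/c1ccc2ccccc2n1)Nc1ccccc1Br`: > 100000 nM (a limit of the assay)

Compound 3 has no number of its own, only a limit, and it shares that position with compound 1: this is the limit of > 100000 nM in this assay, at which 2 of the 3 values shown sit. Compound 4 `Fc1cccc(NC(=S)N/N=C/c2ccc3ccccc3n2)c1` has not yet been measured. Its difference from compound 3 is 3-fluorophenyl in place of 2-bromophenyl on an amide-type nitrogen.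

Among the compounds with values here, three measured steps bear on this change. Removing the 2-fluorophenyl gave an at least 100-fold lower number from compound 1 to compound 2 (2.01 log units; beyond the scatter), and adding the 2-bromophenyl gave an at least 100-fold higher number from compound 2 to compound 3 (2.01 log units; beyond the scatter). Both are large and beyond the scatter. Changing fluoro to bromo gave a step that the two limits leave unreadable from compound 1 to compound 3, so that swap teaches nothing about size. Within the data shown here, no measured step covers 3-fluorophenyl, so any expectation stays loose. Compound 4 also carries a substituted phenyl on that nitrogen, so it is expected to stay near compound 1 and compound 3, far from compound 2. The estimated change is modest, an at least 2.0-fold lower number from compound 3 to compound 4 (0.30 log units; that floor lies within the scatter), toward a lower number if any is seen. For compound 4 the expected value is 50000 nM, with an estimated range from 8000 nM to 100000 nM.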

Compound 4, half-maximal inhibitory concentration: 70100 nM
The estimate for compound 4 lay 1.4-fold (0.15 log units) below the measured number; measured number inside the range.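

In this assay, within the data shown here, compound 4 is the first compound with a substituted phenyl on the amide-type nitrogen to give a number rather than a limit, yet 3-fluorophenyl in place of hydrogen still leaves a 73-fold higher number from compound 2 to compound 4 (1.86 log units; beyond the scatter). Against the two other phenyl compounds the readings are an at least 1.4-fold lower number from compound 3 to compound 4 (0.15 log units; that floor lies within the scatter) and an at least 1.4-fold lower number from compound 1 to compound 4 (0.15 log units; that floor lies within the scatter), so neither floor shows a gain beyond the scatter, although the true steps could be larger. These two steps remain floors because compound 1 and compound 3 each give only a limit: the limit of > 100000 nM in this assay, at which 2 of the 4 values shown sit.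

The compounds shown leave open whether a methyl or a longer chain on that nitrogen would stay close to compound 2. They also leave open whether a phenyl carrying a carboxylic acid or an amine would behave like compound 4.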